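Replacing methyl with (4-nitrophenyl)sulfonyl in compound 2

The source may hold more compounds than are shown below. What is called first, only, known or untested is meant among the compounds shown, and "the series" means these compounds.

Measured in a functional assay on SMMC-7721 cells (Homo sapiens) for cytotoxicity, read by MTT assay, with a stated time of 24 h; a higher number here means a weaker inhibitor, a lower number a stronger inhibitor:
compound 1 `CN1C/C(=C\c2ccncc2)C(=O)/C(=C/c2ccccc2F)C1`: 7000 nM
compound 2 `CN1C/C(=C\c2ccncc2)C(=O)/C(=C/c2ccccc2C(F)(F)F)C1`: 4100 nM
compound 3 `O=C1/C(=C/c2cccnc2)CN(S(=O)(=O)c2ccc(Br)cc2)C/C1=C\c1ccccc1C(F)(F)F`: 5760 nM

Compound 2, at 4100 nM, has the lowest number of the three, but its gaps to compound 1 and compound 3 both lie within the scatter, so the three values cannot be ranked on this evidence.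

The next compound is compound 4 `O=C1/C(=C/c2ccncc2)CN(S(=O)(=O)c2ccc([N+](=O)[O-])cc2)C/C1=C\c1ccccc1C(F)(F)F`, which is still to be measured in this assay. It carries (4-nitrophenyl)sulfonyl in place of methyl on an amine nitrogen in a ring.

Going by the values given here, the only measured step is a 1.7-fold lower number from compound 1 to compound 2 (0.23 log units; within the scatter). It concerns trifluoromethyl in place of fluoro on an aromatic carbon, lies within the scatter, and says nothing directly about a change on the amine nitrogen. Among the compounds with values here, no measured step isolates that change. The nearest guide is compound 3 at 5760 nM, which also has a sulfonyl group on that nitrogen but differs from compound 4 elsewhere. Its value lies within the scatter of the value of compound 2, so no step beyond the scatter is expected.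

The expected change is a 1.1-fold higher number from compound 2 to compound 4 (0.04 log units; within the scatter). The estimate for compound 4 is 4500 nM, with an expected range of 1500 nM to 13000 nM.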

Compound 4, half-maximal inhibitory concentration: > 20000 nM
Compound 4: no number, only a limit; the forecaster's own chance of this, stated with the estimate: 5%; middle value at least 4.4-fold (0.64 log units) away from the limit.
By their numbers in this assay, from the lowest: compounds 2, 3 and 1 (each within the scatter of the next). At a limit, above all of these: compound 4.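

In this assay, compound 4 is recorded only as a limit, > 20000 nM. Going by these compounds alone, the change on the amine nitrogen in the ring, (4-nitrophenyl)sulfonyl in place of methyl, gives an at least 4.8-fold higher number from compound 2 to compound 4 (0.68 log units; beyond the scatter), the first step in this set to isolate this position and the first to lie beyond the scatter. This shows that the group on this nitrogen can change the reading in this assay, whereas the earlier step, on an aromatic carbon, stayed within the scatter, although the size of the new step remains open on one side as it rests on a limit: the limit of > 20000 nM in this assay, at which 1 of the 4 values shown sits.

With only one pair at this position, the compounds shown do not separate the contribution of the sulfonyl unit from that of the nitro-bearing aromatic ring, so it remains open how a plain benzenesulfonyl, an acetyl or a benzyl group on the same nitrogen would read. They also leave open how far the reading of compound 4 lies past its limit, and whether the same change would give a similar step with fluoro in place of trifluoromethyl on the aromatic carbon.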